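Sulfonamide for amide on a smaller lactam core

The source may report more compounds than this note shows. Statements on the series, on what has been measured and on what is new or still open speak of the compounds shown alone.

Measured so far in an assay on cells for inhibition of cytochrome P450 11B2, mitochondrial (Homo sapiens), read by HTRF; on this read-out lower numbers stand for stronger inhibition and higher numbers for weaker inhibition:
compound 1, `CCC(=O)N[C@@H]1CCCc2c1cncc2N1CCc2cc(Cl)ccc2C1=O`: 119 nM
compound 2, `CS(=O)(=O)N[C@@H]1CCCc2c1cncc2N1CCc2cc(Cl)ccc2C1=O`: 76 nM
compound 3, `CCC(=O)N[C@@H]1CCCc2c1cncc2N1Cc2cc(Cl)ccc2C1=O`: 28 nM

Compound 3 stands lowest of the three in this assay, beyond the scatter from both compound 1 and compound 2. The difference between the core of compound 3 and the core of compound 1 is not broken down here. Within the core of compound 1, the change methylsulfonyl in place of propanoyl on an amine nitrogen gave a 1.6-fold lower number from compound 1 to compound 2 (0.19 log units; within the scatter). Compound 4, `CS(=O)(=O)N[C@@H]1CCCc2c1cncc2N1Cc2cc(Cl)ccc2C1=O`, carries the same change on the core of compound 3, (methylsulfonyl in place of propanoyl on an amine nitrogen), at the same place. Since the earlier step with compound 1 and compound 2 was within the scatter, a step of similar size, a 1.5-fold lower number from compound 3 to compound 4 (0.17 log units; within the scatter), is expected for compound 4. Compound 4 is therefore estimated at 19 nM in this assay, with a likely range from 8 nM to 45 nM.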

Compound 4, half-maximal inhibitory concentration: 998 nM
Compound 4: middle estimate off by 53-fold (1.72 log units), on the low side, outside the stated range (above it).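

The new step, methylsulfonyl in place of propanoyl on an amine nitrogen, is a 36-fold higher number from compound 3 to compound 4 (1.55 log units; beyond the scatter) in this assay. The same change does not carry over from one core to the other in this series, and its size and direction depend on the core that bears it: the same change on two cores in this assay, a 1.6-fold lower number (0.19 log units; within the scatter) from compound 1 to compound 2 and a 36-fold higher number (1.55 log units; beyond the scatter) from compound 3 to compound 4, 56-fold (1.75 log units) apart, beyond the scatter of two such steps This rests on a single pair of steps, so it shows that the two cores respond differently, but not which feature of the cores produces the difference or how the change would behave on a further core.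

The compounds shown leave open whether the rise belongs to methylsulfonyl alone. An ethylsulfonyl or acetyl group on the core of compound 3 would help to settle this.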